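Thiophene Replaces Methoxyphenyl on a Shared Core

The source may report more compounds than this note shows. Statements on the series, on what has been measured and on what is new or still open speak of the compounds shown alone.

Two measured compounds share one core and differ only in the aryl group attached to a single aromatic carbon. Compound 1 `O=Cc1ccc(-c2cn3ccnc3c(-c3ccc4ncn(C5CCCCC5)c4c3)n2)cc1` carries a 4-formylphenyl group there; in a functional assay on SK-MEL-5 cells (Homo sapiens) for inhibition, read by sulforhodamine B assay, with a stated time of 48 h, tested at 10 uM (on this read-out lower numbers stand for less inhibition and higher numbers for more inhibition at the one concentration tested (going by the name of the read-out)), compound 1 gives 56.5%. Compound 2 `COc1ccccc1-c1cn2ccnc2c(-c2ccc3ncn(C4CCCCC4)c3c2)n1` carries a 2-methoxyphenyl group instead, and in this assay compound 2 gives 8.94%. Among the compounds with values here, the step of a number 47.6 percentage points lower from compound 1 to compound 2 (beyond the scatter) is the only one recorded, so compound 2 holds the lowest of the two numbers, with compound 1 as its sole neighbour well above it.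

Compound 3 `c1csc(-c2cn3ccnc3c(-c3ccc4ncn(C5CCCCC5)c4c3)n2)c1` is the unmeasured candidate: thiophen-2-yl in place of 2-methoxyphenyl on an aromatic carbon. Within the data shown here, no measured step sets a thiophen-2-yl against either aryl group, so the guidance rests on the step of a number 47.6 percentage points lower from compound 1 to compound 2 (beyond the scatter), which shows that the group at this position can move the read-out far beyond the scatter. Since compound 2 sits near the floor, room to fall is small, and a move upward is the more likely outcome, though its size is uncertain. An upward step is expected, estimated as a number 16.1 percentage points higher from compound 2 to compound 3 (beyond the scatter). Compound 3 is estimated at 25%, with a range from 3% to 55%.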

Compound 3, a percentage reported as inhibition, at one concentration (the size of the read-out at that concentration, not a potency): 8.05%
For compound 3 the middle estimate is 17 percentage points above the measured one; low and high end bracket the measured number.
By their numbers in this assay, from the lowest: compounds 3 and 2 (each within the scatter of the next); then compound 1.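

In this assay, the step of a number 0.9 percentage points lower from compound 2 to compound 3 (within the scatter) shows that compounds carrying thiophen-2-yl and 2-methoxyphenyl at this aromatic carbon cannot be told apart, even though one group is a five-membered aromatic ring with a sulfur atom and the other a six-membered carbon ring bearing an oxygen-linked substituent. The step of a number 48.5 percentage points lower from compound 1 to compound 3 (beyond the scatter) adds a second large drop from the 4-formylphenyl compound, so the high number of compound 1 is not reproduced by either of the two other aryl groups, and among these three compounds the 4-formylphenyl group alone stands apart. Nothing available accounts for this difference between the aryl groups.

The three compounds leave open whether the number of compound 1 depends on the formyl group itself or would also be reached with other substituents on a phenyl ring at this carbon. An unsubstituted phenyl, a 4-methoxyphenyl, a 4-carboxyphenyl or a 4-(aminomethyl)phenyl group would each test this on the shared core, and the three compounds give no guide to what any of them would read.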